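A few compounds are considered here, and "the series" means these few. Any claim that something is new, unique, unknown or untested is made for them only; others in the source may bear on it.

Three compounds share one core and were examined for how harmful they are to cultured cells. Compound 1 `C[C@]1(CN2CCc3nc(-c4ccc(F)c(F)c4)oc3C2)Cn2cc([N+](=O)[O-])nc2O1` was tested in an ADME assay on Vero cells (Chlorocebus sabaeus) for cytotoxicity, read by MTT assay, with a stated time of 72 h; on this read-out higher numbers stand for lower toxicity in this test and lower numbers for higher toxicity in this test; for compound 1 the assay reports a limit, > 32 ug/mL, rather than a number. Compound 2 `C[C@]1(CN2CCn3cc(-c4ccc(F)c(F)c4)nc3C2)Cn2cc([N+](=O)[O-])nc2O1` has no result in this assay; for compound 2 the entry reads "not determined" (no result reported). Going by the values given here, compound 3 `C[C@]1(CN2CCc3nc(C4CCCCC4)ccc3C2)Cn2cc([N+](=O)[O-])nc2O1` likewise has no result in this assay; for compound 3 the entry reads "not determined" (no result reported), so nothing is known of where it stands; the only value in the set is the limit of > 32 ug/mL in this assay, at which 1 of the 3 values shown sits. Compound 4 `C[C@]1(CN2CCc3nc(-c4cc(F)ccc4F)ccc3C2)Cn2cc([N+](=O)[O-])nc2O1` differs from compound 3 in one place: 2,5-difluorophenyl in place of cyclohexyl on an aromatic carbon. Among the compounds with values here, no measured step between two compounds exists, so the size of this step in this assay cannot be read from the data; the expectation is a change no larger than the scatter, in no particular direction. Compound 4 is therefore expected to give about 32 ug/mL, within 10 ug/mL to 64 ug/mL.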

Compound 4, half-maximal cytotoxic concentration: > 32 ug/mL
Compound 4 ended at the assay's limit; the forecaster's own chance of this, stated with the estimate: 65%; the middle value lies on the limit itself.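

Going by these compounds alone, no step between compound 3 and compound 4 can be read in this assay, and compound 4 stands at a limit, like compound 1: the limit of > 32 ug/mL in this assay, at which 2 of the 4 values shown sit. The compounds shown leave open what swapping cyclohexyl for 2,5-difluorophenyl does to toxicity in these cells.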